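Chloro to fluoro swap on the pendant phenyl: cytotoxicity notes

The source may report more compounds than this note shows. Statements on the series, on what has been measured and on what is new or still open speak of the compounds shown alone.

The series shares the core of compound 1 `O=C(O)c1cccc(-c2ccc(/C=C3\S/C(=N\c4ccc(Cl)cc4)N(c4ccc(Cl)cc4)C3=O)o2)c1`. In an ADME assay on Vero cells (Chlorocebus sabaeus) for cytotoxicity (on this read-out lower numbers stand for higher toxicity in this test and higher numbers for lower toxicity in this test), compound 1 gives only a limit, > 200000 nM. Compound 2 `O=C(O)c1cccc(-c2ccc(/C=C3\S/C(=N\c4ccc(F)cc4)N(c4ccc(F)cc4)C3=O)o2)c1` likewise reaches only a limit in this assay, > 200000 nM. Compound 3 `O=C(O)c1cccc(-c2ccc(/C=C3\S/C(=N\c4ccccc4)N(c4ccc(Cl)cc4)C3=O)o2)c1` also gives a limit in this assay, > 200000 nM, so it stands, like the other two, only at a limit rather than a number. Among the measured compounds shown here, the single measured step, a step that the two limits leave unreadable from compound 1 to compound 3, cannot be read for size. Compound 4 `O=C(O)c1cccc(-c2ccc(/C=C3\S/C(=N\c4ccccc4)N(c4ccc(F)cc4)C3=O)o2)c1` differs from compound 3 by fluoro in place of chloro on an aromatic carbon. For the measured compounds named here, no measured step matches this change; the only bearing comes from the limit of > 200000 nM in this assay, at which 3 of the 3 values shown sit. The step from compound 3 to compound 4 is expected to be a step that the limit leaves unreadable from compound 3 to compound 4, none beyond the scatter. Compound 4 is expected at 300000 nM, ranging 150000 nM to 1000000 nM, most likely again only a limit.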

Compound 4, half-maximal cytotoxic concentration: > 200000 nM
Compound 4 ended at the assay's limit; the forecaster's own chance of this, stated with the estimate: 85%; the middle value is on the limit's open side.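

In this assay compound 4 gives only a limit, > 200000 nM, so the steps to it from compound 2 and compound 3 cannot be read. The compounds shown leave open whether chloro, fluoro or hydrogen on the aromatic carbon makes any difference to the read-out: the limit of > 200000 nM in this assay, at which 4 of the 4 values shown sit.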